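A few compounds are considered here, and "the series" means these few. Any claim that something is new, unique, unknown or untested is made for them only; others in the source may bear on it.

Measured in a physicochemical assay for permeability, using PAMPA; a lower number here means that the compound crosses the layer more slowly, a higher number that the compound crosses the layer faster:
- Compound 1 `COCCOc1cc2oc(=O)n(CCC(=O)O)c2cc1Cl`: < 3 nm/s (a limit)
- Compound 2 `CC(C)Cc1cc2oc(=O)n(CCC(=O)O)c2cc1Cl`: < 10 nm/s (a limit)
- Compound 3 `C[C@@H](Oc1cc2oc(=O)n(CCC(=O)O)c2cc1Cl)c1ccc(Cl)cn1`: 60 nm/s

Going by the values given here, compound 3 gives 60 nm/s, the only true number among the three. Compound 1 gives only a limit, < 3 nm/s. Compound 2 likewise gives only a limit, < 10 nm/s.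

Compound 4 `C[C@@H](Oc1cc2oc(=O)n(CCC(=O)O)c2cc1Cl)c1ncco1` differs from compound 3 in one place: 1,3-oxazol-2-yl in place of 5-chloropyridin-2-yl on a saturated chain carbon bound to an oxygen on an aromatic ring and a saturated chain carbon.

Among the compounds with values here, the only measured step, a step that the two limits leave unreadable from compound 1 to compound 2, involves a different change and gives no size to carry over. Within the data shown here, no measured step covers this exchange, so the expectation is a rough one. Among the measured compounds shown here, compound 3, at 60 nm/s, is the only compound with the 5-chloropyridin-2-yl group and the only one with a readable number. Three compounds are too few for a rule, but a drop is the more likely direction once that group leaves. The expected change is a 4.0-fold lower number from compound 3 to compound 4 (0.60 log units; beyond the scatter). For compound 4 the estimate is 15 nm/s, with an expected range of 4 nm/s to 45 nm/s.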

Compound 4, apparent permeability: < 3 nm/s
Compound 4: only a limit was reported; the forecaster's own chance of this, stated with the estimate: 30%; middle value at least 5.0-fold (0.69 log units) from the limit.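

In this assay compound 4 gives < 3 nm/s, which is a limit of the assay and not a number. Going by these compounds alone, on the saturated chain carbon bound to an oxygen on an aromatic ring and a saturated chain carbon, 1,3-oxazol-2-yl in place of 5-chloropyridin-2-yl gives an at least 20-fold lower number from compound 3 to compound 4 (1.30 log units; beyond the scatter), the first readable step, and it shows that a change at this one place can by itself have a large effect on the read-out. The steps from compound 1 and from compound 2 to compound 4 have limits at both ends and cannot be read, and compound 4 now shares its limit with compound 1: the limit of < 3 nm/s in this assay, at which 2 of the 4 values shown sit.

The compounds shown do not separate the loss of the chlorine from the change of ring. A plain pyridin-2-yl or a 5-chlorothiophen-2-yl group at the same place would help to tell these apart.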